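A few compounds are considered here, and "the series" means these few. Any claim that something is new, unique, unknown or untested is made for them only; others in the source may bear on it.

Measured in a functional assay on L1210 cells (Mus musculus) for antiproliferative activity; a lower number here means that less compound is needed, a higher number that more compound is needed for the effect:

- compound 1, `CCCCCCCCCCCCO/N=C(\CCCCCC)c1cc(OC)c2c(c1OC)C(=O)C=CC2=O`, gives 0.193 ug/mL
- compound 2, `CCCCCCCO/N=C(\CCCCCC)c1cc(OC)c2c(c1OC)C(=O)C=CC2=O`, gives 0.162 ug/mL
- compound 3, `CCCCCC/C(=N\OCCCCC)c1cc(OC)c2c(c1OC)C(=O)C=CC2=O`, gives 0.224 ug/mL

All three share one core and differ only in the length of the chain on the oxime oxygen. Compound 3 gives the highest of the three numbers, but its neighbours sit close: the step of a 1.2-fold higher number from compound 1 to compound 3 (0.06 log units; within the scatter) and the step of a 1.4-fold higher number from compound 2 to compound 3 (0.14 log units; within the scatter) both fall within the scatter of the measurement, as does the step of a 1.2-fold lower number from compound 1 to compound 2 (0.08 log units; within the scatter). Across this small set, then, the chain length gives no difference that can be told apart from repeat-measurement noise.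

Compound 4, `CCCCCCCCCO/N=C(\CCCCCC)c1cc(OC)c2c(c1OC)C(=O)C=CC2=O`, is the next member of the same series. It differs from compound 3 by butyl in place of hydrogen on a saturated chain carbon, five bonds along the chain from an oxygen on an unsaturated carbon, which places it between compound 2 and compound 1 in chain length. Among the compounds with values here, the steps that bear on this change are the ones already seen: removing heptyl or ethyl from the same kind of position moved the number only within the scatter. A step of similar size, in no clear direction, is therefore expected here, a 1.2-fold lower number from compound 3 to compound 4 (0.09 log units; within the scatter). Compound 4 is estimated at 0.18 ug/mL, with a likely range from 0.09 ug/mL to 0.36 ug/mL.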

Compound 4, concentration for half-maximal effect: 1.15 ug/mL
The estimate for compound 4 lay 6.4-fold (0.81 log units) below the measured number; measured number above the stated range.
By their numbers in this assay, from the lowest: compounds 2, 1 and 3 (each within the scatter of the next); then compound 4.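

Adding to the chain on a saturated chain carbon, five bonds along the chain from an oxygen on an unsaturated carbon, is not always without effect: butyl in place of hydrogen gives a step beyond the scatter (a 5.1-fold higher number from compound 3 to compound 4 (0.71 log units; beyond the scatter)), so more compound is needed, whereas every earlier step among these chains stayed within it. This does not follow chain length in a steady way, as the same gap appears against the shorter heptyl chain (a 7.1-fold higher number from compound 2 to compound 4 (0.85 log units; beyond the scatter)) and against the longer dodecyl chain (a 6.0-fold higher number from compound 1 to compound 4 (0.78 log units; beyond the scatter)), and the dodecyl chain therefore goes against any rule that longer is worse. Nothing at hand accounts for this isolated rise.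

The compounds shown leave open whether the rise belongs to the nonyl chain alone or extends over a wider range of lengths, which an octyl or a decyl chain could help to settle. On these data alone, it is also open how the number would respond to a chain of similar length that ends in an amine or a carboxylic acid.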